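The source may hold more compounds than are shown below. What is called first, only, known or untested is meant among the compounds shown, and "the series" means these compounds.

Measured so far in an in vivo functional assay on the whole organism for inhibition of 3-hydroxy-3-methylglutaryl-coenzyme A reductase (Rattus norvegicus), at a dose of 0.2 mg/kg by the oral route; on this read-out higher numbers stand for a stronger effect at the one dose given and lower numbers for a weaker effect:
compound 1 `Cc1nn(-c2ccccc2)c2nc(C(C)C)c(/C=C/[C@@H](O)C[C@@H](O)CC(=O)O)c(-c3ccc(F)cc3)c12` — 3.3%
compound 2 `CC(C)c1nc2onc(-c3ccccc3)c2c(-c2ccc(F)cc2)c1/C=C/[C@@H](O)C[C@@H](O)CC(=O)O` — 33.7%

Compound 1 stands lowest of the two numbers; compound 2 sits higher by a gap beyond the scatter, but the two structures differ in several places, so no single step can be read from them. Compound 3 `Cc1nn(C(C)(C)C)c2nc(C(C)C)c(/C=C/[C@@H](O)C[C@@H](O)CC(=O)O)c(-c3ccc(F)cc3)c12` differs from compound 1 in one place: tert-butyl in place of phenyl on an aromatic nitrogen. Nothing measured bears directly on a tert-butyl at this aromatic nitrogen. A step upward is expected from compound 1 to compound 3, a number 10.7 percentage points higher from compound 1 to compound 3 (beyond the scatter), of a size that may stay within the scatter. Compound 3 is estimated at 14%, ranging from 0% to 40%.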

Compound 3, a percentage reported as inhibition, in the whole organism at one dose (the size of the read-out at that dose, not a potency): 51.8%
Compound 3: the middle estimate sits 37.8 percentage points below what was measured; measured number outside the range, above it.
By their numbers in this assay, from the lowest: compound 1; then compound 2; then compound 3.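

In this assay, tert-butyl in place of phenyl on the aromatic nitrogen gives a number 48.5 percentage points higher from compound 1 to compound 3 (beyond the scatter) and so shows that the group on this nitrogen strongly shapes the effect at the one dose given. An aromatic ring at this position is not needed for that effect, since the ring-free tert-butyl carries the higher number. Nothing at hand accounts for the size of this step. Open, from the compounds shown here alone, is whether ethyl or cyclohexyl on this nitrogen would hold the higher number, and whether tert-butyl itself is required.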